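The source may hold more compounds than are shown below. What is called first, only, known or untested is meant among the compounds shown, and "the series" means these compounds.

Compound 1, `CCCCCCCCCCCCCCNC(=O)[C@@H](NS(=O)(=O)c1ccc(C)cc1)[C@@H](C)O`: 10900 nM
Compound 2, `CCCCCCCCCCCCCCNC(=O)[C@@H](NS(=O)(=O)c1cccs1)[C@@H](C)O`: 21600 nM
Compound 3, `CCCCCCCCCCCCCCCCCCNC(=O)[C@@H](NS(=O)(=O)c1ccc(C)cc1)[C@@H](C)O`: 75800 nM

These three compounds were tested in a functional assay on HepG2 cells (Homo sapiens) for cytotoxicity, read by MTT assay, with a stated time of 48 h; a lower number here means a stronger inhibitor, a higher number a weaker inhibitor. Compound 1 and compound 2 share one core and differ in one spot: thiophen-2-yl in place of 4-methylphenyl on a sulfonyl sulfur. That change gave a 2.0-fold higher number from compound 1 to compound 2 (0.30 log units; within the scatter). Compound 3 carries a longer chain than compound 1; the difference between the two cores is butyl in place of hydrogen on a saturated chain carbon, ten or more bonds along the chain from an amide-type nitrogen, and it gave a 7.0-fold higher number from compound 1 to compound 3 (0.84 log units; beyond the scatter). Compound 3 stands with the highest number of the three measured in this assay.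

Compound 4, `CCCCCCCCCCCCCCCCCCNC(=O)[C@@H](NS(=O)(=O)c1cccs1)[C@@H](C)O`, has not yet been measured. It differs from compound 3 in one spot: thiophen-2-yl in place of 4-methylphenyl on a sulfonyl sulfur. Going by the values given here, this is the same change as the one from compound 1 to compound 2, made on the same place around a sulfonyl sulfur, but on the core with the longer chain. Resting on the step from compound 1 to compound 2 in this assay, the step from compound 3 to compound 4 is expected to be a 2.0-fold higher number from compound 3 to compound 4 (0.30 log units; within the scatter), beside the earlier 2.0-fold higher number from compound 1 to compound 2 (0.30 log units; within the scatter). Compound 4 is therefore estimated at 150000 nM, between 60000 nM and 350000 nM.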

Compound 4, half-maximal inhibitory concentration: > 200000 nM
Compound 4 ended at the assay's limit (the forecaster's own chance of this, stated with the estimate: 25%); at least 1.3-fold (0.12 log units) between middle value and limit.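

In this assay compound 4 gives > 200000 nM, which is a limit of the assay and not a number. Going by these compounds, putting thiophen-2-yl in place of 4-methylphenyl on the sulfonyl sulfur of the longer-chain core gives an at least 2.6-fold higher number from compound 3 to compound 4 (0.42 log units; beyond the scatter), so the number does not fall on this core, but the size of the step stays unknown and it cannot be said that the change carries over unaltered: the same change on two cores in this assay, a 2.0-fold higher number (0.30 log units; within the scatter) from compound 1 to compound 2 and an at least 2.6-fold higher number (0.42 log units; beyond the scatter) from compound 3 to compound 4; the limit leaves it open whether they differ. The longer chain, read on the compounds bearing thiophen-2-yl, gives an at least 9.2-fold higher number from compound 2 to compound 4 (0.96 log units; beyond the scatter), which again points the same way as on the 4-methylphenyl compounds without fixing how large the step is: the same change on two cores in this assay, a 7.0-fold higher number (0.84 log units; beyond the scatter) from compound 1 to compound 3 and an at least 9.2-fold higher number (0.96 log units; beyond the scatter) from compound 2 to compound 4; the limit leaves it open whether they differ.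

The compounds shown leave open how a shorter chain than that of compound 1 would behave on either sulfonyl group. They also leave open whether other groups on the sulfonyl sulfur, such as a plain phenyl or a furan-2-yl, would follow the same course.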